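This account rests on a few compounds, and the source may have more. Where it says the series, first, only, none or still open, it means among the compounds named here.

Compound 3, `N#CC1=C(N)Oc2c(N)cc3nc4ccccc4nc3c2C12C(=O)N(Cc1cnnn1-c1c(F)cccc1F)c1ccccc12`, stands at the edge of what a functional assay on MCF7 cells (Homo sapiens) for antiproliferative activity, read by MTT assay, with a stated time of 48 h (a higher number here means a weaker inhibitor, a lower number a stronger inhibitor), can resolve: in this assay compound 3 gives only a limit, > 50000 nM. Two of the three values shown share that position, as the limit of > 50000 nM in this assay, at which 2 of the 3 values shown sit, records. Compound 1, `N#CC1=C(N)Oc2c(N)cc3nc4ccccc4nc3c2C12C(=O)N(Cc1cnnn1-c1ccccc1Br)c1ccccc12`, gives 30700 nM in this assay. Compound 2, `CCc1cccc(C)c1-n1nncc1CN1C(=O)C2(C(C#N)=C(N)Oc3c(N)cc4nc5ccccc5nc4c32)c2ccccc21`, likewise returns only a limit in this assay, > 50000 nM. The step of an at least 1.6-fold higher number from compound 1 to compound 2 (0.21 log units; that floor lies within the scatter) and the step of an at least 1.6-fold higher number from compound 1 to compound 3 (0.21 log units; that floor lies within the scatter) both exchange the aryl group on the aromatic nitrogen, and the step that the two limits leave unreadable from compound 2 to compound 3 between the two limits cannot be read. Compound 4, `N#CC1=C(N)Oc2c(N)cc3nc4ccccc4nc3c2C12C(=O)N(Cc1cnnn1-c1ccc(Cl)cc1[N+](=O)[O-])c1ccccc12`, differs from compound 3 by 4-chloro-2-nitrophenyl in place of 2,6-difluorophenyl on an aromatic nitrogen. Neither readable step reaches beyond the scatter, and all three aryl variants sit at or close to the limit, so no change beyond the scatter is expected in this assay, and the expected step of an at least 1.1-fold lower number from compound 3 to compound 4 (0.04 log units; that floor lies within the scatter) is set accordingly. Compound 4 is therefore expected to give 45000 nM in this assay, within 20000 nM and 100000 nM, most probably again as a limit.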

Compound 4, half-maximal inhibitory concentration: > 50000 nM
Compound 4: only a limit was reported (the forecaster's own chance of this, stated with the estimate: 55%); middle value at least 1.1-fold (0.04 log units) away from the limit.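

In this assay compound 4 also returns only a limit, > 50000 nM. Measured against the 2-bromophenyl group, the change gives an at least 1.6-fold higher number from compound 1 to compound 4 (0.21 log units; that floor lies within the scatter), while the steps from compound 2 and from compound 3 to compound 4 cannot be read. The position on the aromatic nitrogen now also holds a 4-chloro-2-nitrophenyl group, the first aryl group shown here with hydrogen-bond acceptors, and still only compound 1 yields a number rather than a limit: the limit of > 50000 nM in this assay, at which 3 of the 4 values shown sit.

The compounds shown leave open whether any group at this position can bring the number clearly away from that limit. On these data alone, what an aryl ring bearing an amine or a carboxylic acid would give here, or a simple alkyl chain in place of the aryl ring, remains open.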